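The source may report more compounds than this note shows. Statements on the series, on what has been measured and on what is new or still open speak of the compounds shown alone.

Measured compounds in a functional assay on A-431 cells (Homo sapiens) for antiproliferative activity, read by MTT assay, with a stated time of 72 h; on this read-out lower numbers stand for stronger inhibition and higher numbers for weaker inhibition:
- compound 1 `COc1cc2ncnc(Nc3ccc(F)c(Cl)c3)c2cc1OCCCCC(=O)Nc1ccc(S(N)(=O)=O)cc1` gives 5020 nM
- compound 2 `COc1cc2ncnc(Nc3ccc(Cl)c(C(F)(F)F)c3)c2cc1OCCCCC(=O)Nc1ccc(S(N)(=O)=O)cc1` gives 3910 nM
- compound 3 `COc1cc2ncnc(Nc3ccc(Br)cc3)c2cc1OCCCCC(=O)Nc1ccc(S(N)(=O)=O)cc1` gives 6570 nM

Compound 3 has the highest of the three numbers, but the steps leading to it are small: a 1.3-fold higher number from compound 1 to compound 3 (0.12 log units; within the scatter) and a 1.7-fold higher number from compound 2 to compound 3 (0.23 log units; within the scatter), both within the scatter, as is a 1.3-fold lower number from compound 1 to compound 2 (0.11 log units; within the scatter). All three compounds therefore sit together on this read-out, and none can be called more or less active than another.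

Compound 4 `COc1ccc(Nc2ncnc3cc(OC)c(OCCCCC(=O)Nc4ccc(S(N)(=O)=O)cc4)cc23)cc1` is not yet measured. It differs from compound 3 in one place: methoxy in place of bromo on an aromatic carbon. Among the compounds with values here, no measured step covers this exchange; the three measured steps all swap one substituted phenyl on the nitrogen of the shared core for another, and none moves the number beyond the scatter. On that basis a step of similar size is expected, a 1.2-fold higher number from compound 3 to compound 4 (0.09 log units; within the scatter), with no firm direction, a slightly higher number being taken as the middle of the range. For compound 4 the expected value in this assay is 8000 nM, with a range from 3000 nM to 25000 nM.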

Compound 4, half-maximal inhibitory concentration: 14700 nM
Compound 4: the middle estimate sits 1.8-fold (0.26 log units) below what was measured, and the stated range covers the measured number.
By their numbers in this assay, from the lowest: compounds 2, 1 and 3 (each within the scatter of the next); then compound 4.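

In this assay, within the data shown here, the exchange of bromo for methoxy on the aromatic carbon para to a large group gives the first step that lies beyond the scatter: a 2.2-fold higher number from compound 3 to compound 4 (0.35 log units; beyond the scatter). The 4-methoxyphenyl group also stands apart from the other two groups on the nitrogen, with a 3.8-fold higher number from compound 2 to compound 4 (0.58 log units; beyond the scatter) and a 2.9-fold higher number from compound 1 to compound 4 (0.47 log units; beyond the scatter), so the substituent at this position can shift the number, though only modestly, while the three halogen-bearing groups remain together. No available evidence bears on this shift.

On these data alone, it remains open whether the higher number is specific to methoxy or would also appear with a hydroxy, ethoxy or dimethylamino group on the same carbon. Unsubstituted phenyl would show whether bromo or methoxy lies closer to the parent group.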